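Acetyl replaces isopentyl on the piperazine nitrogen

The source may hold more compounds than are shown below. What is called first, only, known or untested is meant among the compounds shown, and "the series" means these compounds.

Compound 1, `CS(=O)(=O)N(CC1CC1)c1ccccc1N1CCN(C(=O)[C@H](CC(=O)N2CCNCC2)Cc2ccc(Cl)cc2)CC1`, gives 2000 nM in a functional assay with Melanocortin receptor 4 (Homo sapiens) as the target, read by cAMP accumulation; a higher number here means that more compound is needed for the effect, a lower number that less compound is needed.
Compound 2, `CCN1CCN(C(=O)C[C@H](Cc2ccc(Cl)cc2)C(=O)N2CCN(c3ccccc3N(CC3CC3)S(C)(=O)=O)CC2)CC1`, gives in this assay only a limit, > 10000 nM.
Compound 3, `CC(C)CCN1CCN(C(=O)C[C@H](Cc2ccc(Cl)cc2)C(=O)N2CCN(c3ccccc3N(CC3CC3)S(C)(=O)=O)CC2)CC1`, gives in this assay only a limit, > 10000 nM.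
Compound 4, `CC(=O)N1CCN(C(=O)C[C@H](Cc2ccc(Cl)cc2)C(=O)N2CCN(c3ccccc3N(CC3CC3)S(C)(=O)=O)CC2)CC1`, has not yet been measured in this assay.

Compound 3 thus stands at the limit of this assay, with no number of its own; it shares this position with one other compound, since (the limit of > 10000 nM in this assay, at which 2 of the 3 values shown sit). The change that leads to compound 4 is acetyl in place of isopentyl on an amine nitrogen in a ring. For the measured compounds named here, two measured steps touch the same ring nitrogen: an at least 5.0-fold higher number from compound 1 to compound 2 (0.69 log units; beyond the scatter) and an at least 5.0-fold higher number from compound 1 to compound 3 (0.69 log units; beyond the scatter), both of them weakening. The step between the two alkylated compounds, a step that the two limits leave unreadable from compound 2 to compound 3, cannot be sized. Going by the values given here, none of these steps exchanges an alkyl group for an acetyl group, so the direction for compound 4 is uncertain; the only compound with a full number is compound 1, and compound 4 may land anywhere between that number and the limit. Compound 4 is therefore estimated at 8000 nM, within 2000 nM to 30000 nM, which would mean an at least 1.2-fold lower number from compound 3 to compound 4 (0.09 log units; that floor lies within the scatter), with a real chance that again only a limit is reported.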

Compound 4, half-maximal effective concentration: > 10000 nM
Compound 4: a limit, no number (the forecaster's own chance of this, stated with the estimate: 45%); at least 1.2-fold (0.09 log units) between middle value and limit.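

Acetyl on the ring nitrogen gives an at least 5.0-fold higher number from compound 1 to compound 4 (0.69 log units; beyond the scatter) in this assay, the same direction as the ethyl and isopentyl steps from compound 1. The loss is therefore not confined to alkyl groups: among the compounds shown, only compound 1, with hydrogen on this nitrogen, gives a number, and none of the others goes against that. Exchanging isopentyl for acetyl brings in a carbonyl and a hydrogen-bond acceptor without restoring a number, and the steps among compound 2, compound 3 and compound 4 cannot be read because all three values are limits: the limit of > 10000 nM in this assay, at which 3 of the 4 values shown sit.

As far as these compounds go, how far these three compounds lie from one another, and how much weaker than compound 1 each truly is, stays open. Also open, from the compounds shown here alone, is whether another group on this nitrogen, such as methyl or a short chain ending in an amine, would keep a measurable value, as compound 1 does with 2000 nM.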